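The compounds below may be only part of what the source reports. "The series", "measured", "known", "first", "only" and "open" are said of these compounds alone.

Of the compounds shown here, two from this study share a core and have been tested in a functional assay on NCI-H23 cells (Homo sapiens) for inhibition, read by sulforhodamine B assay, with a stated time of 48 h; on this read-out lower numbers stand for stronger inhibition of growth and higher numbers for weaker inhibition of growth. Compound 1 `Nc1cc(N)c2nc(-c3ccccc3)c(Oc3ccc(Cl)c(Cl)c3)nc2c1` gives 39800 nM in this assay. Compound 2 `CCOC(=O)[C@H](CCC(=O)O)NC(=O)c1ccc(Oc2nc3cc(N)cc(N)c3nc2-c2ccccc2)cc1` gives 30200 nM in this assay, and the two numbers lie within the usual scatter of each other, so neither can be called the stronger one. Compound 3 `Nc1cc(N)c2nc(-c3ccccc3)c(Sc3ccc(F)cc3)nc2c1` is still to be measured; it differs from compound 1 by (4-fluorophenyl)sulfanyl in place of 3,4-dichlorophenoxy on an aromatic carbon. Among the measured compounds shown here, no measured pair shows how such a change acts, so the step is expected to stay within the scatter, with no clear direction, a 1.0-fold higher number from compound 1 to compound 3 (0.00 log units; within the scatter). Compound 3 is accordingly expected to give about 40000 nM in this assay, in a range from 13000 nM to 100000 nM.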

Compound 3, concentration for total growth inhibition: 39800 nM
Beside the measured number, compound 3's estimate is 1.0-fold (0.00 log units) above it; low and high end bracket the measured number.
By their numbers in this assay, from the lowest: compounds 2, 1 and 3 (each within the scatter of the next).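

Putting (4-fluorophenyl)sulfanyl in place of 3,4-dichlorophenoxy on this aromatic carbon gives, in this assay, no change at the digits printed from compound 1 to compound 3 (within the scatter). Among the compounds shown here, this is the first direct reading at this position, and it shows that two different aryl groups can occupy it with no visible difference in growth inhibition. Nothing measured here explains why the two compounds read alike. Going by these compounds, the linking atom and the ring halogens differ together, so their separate contributions remain unknown. On these data alone, whether an amine or a carboxylic acid at this position would read differently also stays open.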